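This account rests on a few compounds, and the source may have more. Where it says the series, first, only, none or still open, it means among the compounds named here.

Among the compounds with values here, compound 1 `O=c1cc(I)n([C@@H]2O[C@H](CO)[C@@H](O)[C@H]2O)c(=O)[nH]1` is the only compound of the three with a number in a functional assay on cells (Homo sapiens) for antiproliferative activity, read by WST assay, with a stated time of 3 days; a higher number here means a weaker inhibitor, a lower number a stronger inhibitor: compound 1 gives 27800 nM. Compound 2 `CNc1cc(=O)[nH]c(=O)n1[C@@H]1O[C@H](CO)[C@@H](O)[C@H]1O` reaches only a limit of this assay, > 50000 nM. Compound 3 `O=Cc1cc(=O)[nH]c(=O)n1[C@@H]1O[C@H](CO)[C@@H](O)[C@H]1O` likewise stops at a limit, > 50000 nM. The step of an at least 1.7-fold higher number from compound 1 to compound 2 (0.25 log units; that floor lies within the scatter) and the step of an at least 1.7-fold higher number from compound 1 to compound 3 (0.25 log units; that floor lies within the scatter) are each read against (the limit of > 50000 nM in this assay, at which 2 of the 3 values shown sit), and the step that the two limits leave unreadable from compound 2 to compound 3 cannot be read. Compound 4 `CC(=O)OC[C@H]1O[C@@H](n2c(I)cc(=O)[nH]c2=O)[C@H](O)[C@@H]1O` differs from compound 1 by acetyl in place of hydrogen on an oxygen on a saturated carbon. Every measured step changes the substituent on the aromatic carbon, so none bears on a change at the sugar oxygen. Within the data shown here, with no guiding step, the expected step of a 1.1-fold higher number from compound 1 to compound 4 (0.03 log units; within the scatter) is none beyond the scatter, and compound 4 is estimated at 30000 nM, within 12000 nM to 75000 nM.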

Compound 4, half-maximal inhibitory concentration: 1300 nM
Estimate against measurement, compound 4: 23-fold (1.36 log units) above, outside the stated range (below it).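

In this assay, acetyl in place of hydrogen on this oxygen gives a 21-fold lower number from compound 1 to compound 4 (1.33 log units; beyond the scatter). Within the data shown here, the earlier steps all changed the substituent on the aromatic carbon, so this is the first sign that the hydroxymethyl of the sugar matters, with the iodo group left in place. Nothing shown accounts for the size of this step.

The compounds shown leave open whether a butanoyl group or a methyl ether on this oxygen would act like acetyl. They also leave open whether acetyl would bring a similar step with methylamino or formyl in place of iodo.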